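A Methyl Added to the Phenyl Ring of Compound 3

This account rests on a few compounds, and the source may have more. Where it says the series, first, only, none or still open, it means among the compounds named here.

Compound 1 `Cc1ccc(-c2cc3nccc(-c4ccc(F)cc4)n3n2)cc1` in a functional assay on HeLa cells (Homo sapiens) for inhibition, read by CCK-8 assay, with a stated time of 48 h (on this read-out lower numbers stand for stronger inhibition and higher numbers for weaker inhibition), gives > 10000 nM, which is a limit of the assay rather than a number.
Compound 2 `COc1cc(-c2ccnc3cc(-c4ccc(-c5cnn(C)c5)cc4)nn23)cc(OC)c1OC` in this assay gives 1830 nM.
Compound 3 `COc1cc(-c2ccnc3cc(-c4ccccc4)nn23)cc(OC)c1OC` in this assay gives 458 nM.

Among the numbers shown, compound 3 stands lowest, and its only numbered neighbour is compound 2. Within the data shown here, the one measured step, a 4.0-fold lower number from compound 2 to compound 3 (0.60 log units; beyond the scatter), came with hydrogen in place of 1-methyl-1H-pyrazol-4-yl on an aromatic carbon. Compound 1 sits at the limit of > 10000 nM in this assay, at which 1 of the 3 values shown sits, so it offers no number to compare.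

Compound 4 `COc1cc(-c2ccnc3cc(-c4cccc(C)c4)nn23)cc(OC)c1OC` differs from compound 3 by methyl in place of hydrogen on an aromatic carbon. A methyl group enters on an aromatic carbon of a six-membered aromatic ring of carbon only, meta to a large group; read one bond further out, phenyl becomes 3-methylphenyl.

Among the measured compounds shown here, no measured step involves a methyl. The step from compound 2 to compound 3 concerns a much larger group leaving the same ring, so it bears only loosely on this change. A small step in this assay is therefore expected, not clearly beyond the scatter in either direction. For compound 4 the expected value is 450 nM, with a range from 180 nM to 1200 nM. That estimate amounts to an expected step of a 1.0-fold lower number from compound 3 to compound 4 (0.01 log units; within the scatter).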

Compound 4, half-maximal inhibitory concentration: 4230 nM
Compound 4: middle estimate off by 9.4-fold (0.97 log units), on the low side, and the stated range ends below it.
By their numbers in this assay, from the lowest: compound 3; then compound 2; then compound 4. At a limit, above all of these: compound 1.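

In this assay, adding only a methyl to the phenyl ring gives a 9.2-fold higher number from compound 3 to compound 4 (0.97 log units; beyond the scatter), so this carbon, meta to a large group, does not accept even this small group without a clear loss of inhibition. Among these compounds, the only earlier step on this ring involved a much larger group and gave a 4.0-fold lower number from compound 2 to compound 3 (0.60 log units; beyond the scatter); together, the two steps leave compound 3, with its unsubstituted phenyl, at the lowest number, and both compound 2 and compound 4, which carry a group on that ring, at higher numbers, even though methyl is far smaller than 1-methyl-1H-pyrazol-4-yl. Nothing measured for these compounds explains why the methyl has this effect.

Going by these compounds, it remains open whether an amine, a hydroxyl group or a chlorine atom on this same carbon would behave like the methyl or be better tolerated. On these data alone, it is also open whether a methyl placed elsewhere on the phenyl ring would cost as much, or whether this loss is particular to the carbon used in compound 4.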